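The source may report more compounds than this note shows. Statements on the series, on what has been measured and on what is new or still open speak of the compounds shown alone.

Working notes on the series. Compound 2 `CNC(=O)c1cc(Oc2ccc3c(C)c(C(=O)OC)sc3c2)ccn1` and compound 1 `CCOC(=O)c1sc2cc(Oc3ccnc(C(=O)NC)c3)ccc2c1C` share a core and differ by methyl in place of hydrogen on a saturated chain carbon bound to an oxygen next to a carbonyl group. In an ADME assay on H1-HeLa cells (Homo sapiens) for cytotoxicity, read by MTT assay, with a stated time of 3 days (on this read-out higher numbers stand for lower toxicity in this test and lower numbers for higher toxicity in this test), compound 2 gives 10800 nM, and compound 1 gives 50900 nM, so the step of a 4.7-fold higher number from compound 2 to compound 1 (0.67 log units; beyond the scatter). Compound 3 `CCOC(=O)c1ccc2ccc(Oc3ccnc(C(=O)NC)c3)cc2c1` carries a different core; the difference between the two cores is not broken down here. In this assay compound 3 gives 20800 nM, a value that sits within the scatter of compound 2. Compound 4 `CNC(=O)c1cc(Oc2ccc3ccc(C(=O)OC(C)C)cc3c2)ccn1` differs from compound 3 by methyl in place of hydrogen on a saturated chain carbon bound to an oxygen next to a carbonyl group and a saturated chain carbon. This is the same kind of change as from compound 2 to compound 1, though the place differs: here the carbon is bound to an oxygen next to a carbonyl group and to a saturated chain carbon, there only to the oxygen. Because a 4.7-fold higher number from compound 2 to compound 1 (0.67 log units; beyond the scatter) went upward, a step of a 2.4-fold higher number from compound 3 to compound 4 (0.38 log units; beyond the scatter) is expected, smaller since the place is not identical. Compound 4 is estimated at 50000 nM, between 20000 nM and 120000 nM.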

Compound 4, half-maximal cytotoxic concentration: 13800 nM
Compound 4: middle estimate off by 3.6-fold (0.56 log units), on the high side, outside the stated range (below it).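

In this assay the step from ethoxycarbonyl to isopropoxycarbonyl reads a 1.5-fold lower number from compound 3 to compound 4 (0.18 log units; within the scatter), so the added methyl gives no readable change on this core. Set beside the earlier step, the change does not carry over in size from one core to the other: the same change on two cores in this assay, a 4.7-fold higher number (0.67 log units; beyond the scatter) from compound 2 to compound 1 and a 1.5-fold lower number (0.18 log units; within the scatter) from compound 3 to compound 4, 7.1-fold (0.85 log units) apart, beyond the scatter of two such steps. This shows that the rise seen on the core of compound 1 cannot be assumed on the core of compound 3, but it does not show why the steps differ, since they differ in place as well as in core, and the two effects cannot be separated here.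

The compounds shown leave open how a carboxylic acid in place of ethoxycarbonyl would read on either core. Also open, from the compounds shown here alone, is whether a longer chain in place of isopropyl would follow either step.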